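The source may hold more compounds than are shown below. What is called first, only, known or untested is meant among the compounds shown, and "the series" means these compounds.

compound 1 `COc1ccc(-c2ccccc2C(=O)/C=C/c2ccc(F)cc2)cc1OC`: 6800 nM
compound 2 `COc1ccc(/C=C/C(=O)c2ccccc2-c2ccc(F)cc2)cc1`: 61 nM

In a functional assay on SW480 cells (Homo sapiens) for antiproliferative activity, read by sulforhodamine B assay, with a stated time of 48 h (on this read-out lower numbers stand for stronger inhibition and higher numbers for weaker inhibition), compound 2 holds the lower of the two numbers, at 61 nM, and its gap to compound 1 lies beyond the usual scatter. Compound 3 `COc1ccc(/C=C/C(=O)c2ccccc2-c2ccc(F)cc2)cc1O` differs from compound 2 in one place: hydroxy in place of hydrogen on an aromatic carbon. A hydroxy replaces a hydrogen on an aromatic carbon, ortho to a methoxy group and meta to a large group. Within the data shown here, no measured pair shows this change, so only a modest, uncertain shift towards stronger inhibition, within the scatter, is expected. The expected change is a 1.5-fold lower number from compound 2 to compound 3 (0.18 log units; within the scatter). For compound 3 the estimate is 40 nM, with an expected range from 10 nM to 200 nM.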

Compound 3, half-maximal inhibitory concentration: 57 nM
Beside the measured number, compound 3's estimate is 1.4-fold (0.15 log units) below it; the range from low to high includes it.
By their numbers in this assay, from the lowest: compounds 3 and 2 (each within the scatter of the next); then compound 1.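

In this assay the hydroxy gives a 1.1-fold lower number from compound 2 to compound 3 (0.03 log units; within the scatter) and so the two numbers cannot be told apart. Among these compounds, this is the first measured pair for this change, and it shows that this aromatic carbon, ortho to a methoxy group and meta to a large group, can carry a hydroxy with no measurable loss or gain. Nothing measured here explains that result. On these data alone, whether an amine or a carboxylic acid on this carbon would behave the same stays open, as does a longer chain on the hydroxy oxygen.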